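Triazole substituent swap in a dichlorophenyl aminomethyl series

The source may hold more compounds than are shown below. What is called first, only, known or untested is meant among the compounds shown, and "the series" means these compounds.

Measured so far in an assay on isolated protein for inhibition of Dipeptidyl peptidase 9 (Homo sapiens); a higher number here means a weaker inhibitor, a lower number a stronger inhibitor:
compound 1 `Cc1nc2cc(-c3ccccc3)nn2c(-c2ccc(Cl)cc2Cl)c1CN` gives > 20000 nM, a limit of the assay.
compound 2 `Cc1nc2nc(-c3ccccc3)nn2c(-c2ccc(Cl)cc2Cl)c1CN` gives > 30000 nM, a limit of the assay.
compound 3 `COC(=O)c1nc2nc(C)c(CN)c(-c3ccc(Cl)cc3Cl)n2n1` gives > 30000 nM, a limit of the assay.

Compound 3 stands at the limit of > 30000 nM in this assay, at which 2 of the 3 values shown sit, a position it shares with compound 2, while compound 1 sits at the limit of > 20000 nM in this assay, at which 1 of the 3 values shown sits. For the measured compounds named here, the only single-point step measured, a step that the two limits leave unreadable from compound 2 to compound 3, cannot be read in size or direction. Compound 4 `Cc1nc2nc(N3CCCC3)nn2c(-c2ccc(Cl)cc2Cl)c1CN` differs from compound 3 by pyrrolidin-1-yl in place of methoxycarbonyl on an aromatic carbon. Going by the values given here, no measured step resembles this change, and none of the three values is a number that could anchor a direction, so no step beyond the scatter is expected either way. Compound 4 is expected at 40000 nM (5000 nM to 300000 nM), an estimated step that the limit leaves unreadable from compound 3 to compound 4, with a limit the most likely report once more.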

Compound 4, inhibition constant: > 30000 nM
Compound 4 ended at the assay's limit; the forecaster's own chance of this, stated with the estimate: 75%; the middle value does not contradict the limit.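

In this assay compound 4 gives > 30000 nM, a limit of the assay. The steps to compound 4 from compound 2 and from compound 3 join two limits and cannot be read. On these data alone, whether any group on this aromatic carbon gives a true number in this assay stays open.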